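Three pyridine-core phenols and an isomeric fourth compound

The source may hold more compounds than are shown below. What is called first, only, known or untested is meant among the compounds shown, and "the series" means these compounds.

For the measured compounds named here, compound 3 `Oc1ccc(-c2cc(-c3ccccn3)nc(-c3ccccc3Cl)c2)cc1` holds the lowest of the three numbers so far. In an assay on isolated protein for inhibition of DNA topoisomerase 1 (Homo sapiens), with a stated time of 30 min, tested at 100 uM (a lower number here means a weaker effect, a higher number a stronger effect of the compound at the concentration tested), compound 3 gives 5.2%. Compound 2 `Oc1ccc(-c2cc(-c3ccncc3)nc(-c3ccc(Cl)cc3)c2)cc1` gives 5.9% in this assay, a number that sits within the scatter of compound 3. Compound 1 `Oc1cccc(-c2cc(-c3ccc(Cl)cc3)nc(-c3ccccn3)c2)c1` gives 30% in this assay, beyond the scatter above compound 3. Compound 4 `Oc1ccc(-c2cc(-c3ccc(Cl)cc3)nc(-c3ccccn3)c2)cc1` differs from compound 3 in one place: 4-chlorophenyl in place of 2-chlorophenyl on an aromatic carbon. Going by the values given here, no pair of measured compounds differs in just this way, so the step carries no measured precedent. The expected step from compound 3 to compound 4 in this assay is a number 6.8 percentage points higher from compound 3 to compound 4 (within the scatter), a small rise that may well stay within the scatter. Compound 4 is expected to give 12% in this assay, estimated range 0% to 35%.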

Compound 4, a percentage reported as inhibition, at one concentration (the size of the read-out at that concentration, not a potency): 12.7%
The estimate for compound 4 lay 0.7 percentage points below the measured number, and the stated range covers the measured number.
By their numbers in this assay, from the lowest: compounds 3, 2 and 4 (each within the scatter of the next); then compound 1.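

In this assay, 4-chlorophenyl in place of 2-chlorophenyl gives a number 7.5 percentage points higher from compound 3 to compound 4 (within the scatter) and pyridin-2-yl in place of pyridin-4-yl gives a number 6.8 percentage points higher from compound 2 to compound 4 (within the scatter), so neither single change separates from the scatter. Only the hydroxyl placement does: 4-hydroxyphenyl in place of 3-hydroxyphenyl gives a number 17.3 percentage points lower from compound 1 to compound 4 (beyond the scatter), a modest step. No measured evidence bears on why these steps differ. Open, from the compounds shown here alone, is whether the step between the hydroxyphenyl groups holds with 2-chlorophenyl or pyridin-4-yl in the compound. Also open, going by these compounds, is what a methoxy group or an amine in place of the hydroxyl would give.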